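Methoxy for cyano on the benzamide ring of a chromone series

A few compounds are considered here, and "the series" means these few. Any claim that something is new, unique, unknown or untested is made for them only; others in the source may bear on it.

Compound 3 `COc1cc2oc(-c3cccc(NC(=O)c4cccc(C#N)c4)c3)cc(=O)c2c(OC)c1OC` carries a 3-cyanophenyl on the carbonyl carbon of its amide. In a functional assay on HepG2 cells (Homo sapiens) for inhibition, read by MTT assay (on this read-out higher numbers stand for weaker inhibition of growth and lower numbers for stronger inhibition of growth), compound 3 gives 11900 nM. Its two companions differ only in that group: compound 1 `COc1cc2oc(-c3cccc(NC(=O)c4ccc(Br)cc4)c3)cc(=O)c2c(OC)c1OC` has a 4-bromophenyl there and gives 8850 nM in this assay, while compound 2 `COc1cc2oc(-c3cccc(NC(=O)c4ccccc4Br)c3)cc(=O)c2c(OC)c1OC` has a 2-bromophenyl and gives 23100 nM. The three numbers lie close together: a 1.3-fold higher number from compound 1 to compound 3 (0.13 log units; within the scatter) and a 1.9-fold lower number from compound 2 to compound 3 (0.29 log units; within the scatter), and the only separation that exceeds the scatter is a 2.6-fold higher number from compound 1 to compound 2 (0.42 log units; beyond the scatter).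

Compound 4 `COc1cccc(C(=O)Nc2cccc(-c3cc(=O)c4c(OC)c(OC)c(OC)cc4o3)c2)c1` is reached from compound 3 by one change: methoxy in place of cyano on an aromatic carbon.

For the measured compounds named here, no measured step replaces a cyano by a methoxy, so nothing bears on this exchange directly. What the three measured compounds show is that changes to the substituent on this phenyl ring, whether in its position or in its kind, moved this assay only modestly or not beyond the scatter. On that ground a step no larger than the scatter is expected, a 1.0-fold higher number from compound 3 to compound 4 (0.00 log units; within the scatter), with no direction favoured. Compound 4 is therefore estimated at 12000 nM in this assay, within a range from 5000 nM to 30000 nM.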

Compound 4, concentration for 50% growth inhibition: 7060 nM
Compound 4: middle estimate off by 1.7-fold (0.23 log units), on the high side, within the range that was stated.
By their numbers in this assay, from the lowest: compounds 4, 1, 3 and 2 (each within the scatter of the next, the first and the last beyond it).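

Read in this assay, the exchange of cyano for methoxy gives the first direct look at a change of group with its place on the ring held fixed, and it amounts to a 1.7-fold lower number from compound 3 to compound 4 (0.23 log units; within the scatter), so the 3-methoxyphenyl and 3-cyanophenyl amides cannot be told apart. The new group also cannot be told apart from the 4-bromophenyl group, at a 1.3-fold lower number from compound 1 to compound 4 (0.10 log units; within the scatter), whereas the 2-bromophenyl compound now stands clear of a second companion, at a 3.3-fold lower number from compound 2 to compound 4 (0.51 log units; beyond the scatter), so of all the steps among these compounds, only those from the 2-bromophenyl compound to the 4-bromophenyl and 3-methoxyphenyl compounds exceed the scatter, while its step to the 3-cyanophenyl compound does not. No measurement available here offers a reason for any of these differences.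

The compounds shown leave open how an amine, a carboxylic acid or a longer alkoxy chain on this same aromatic carbon would read in this assay. They also leave open whether a methoxy group elsewhere on this ring would read like compound 4, and whether these small steps hold on any other cell line.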